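A few compounds are considered here, and "the series" means these few. Any claim that something is new, unique, unknown or untested is made for them only; others in the source may bear on it.

The measured compounds and their values:

Compound 1, `O=C(Nc1ccc(Oc2ccnc3[nH]ccc23)cc1)c1nn(-c2ccc(Cl)cc2)ccc1=O`, in a functional assay on PC-3 cells (Homo sapiens) for cytotoxicity, read by MTT assay, with a stated time of 72 h (a lower number here means a stronger inhibitor, a higher number a weaker inhibitor), gives 32400 nM.
Compound 2, `O=C(Nc1ccc(Oc2ccnc3[nH]ccc23)cc1)c1nn(-c2ccc(Br)cc2)ccc1=O`, gives 8040 nM.
Compound 3, `O=C(Nc1ccc(Oc2ccnc3[nH]ccc23)cc1)c1nn(-c2ccc(Br)cc2F)ccc1=O`, gives 12800 nM.

Compound 1 has the highest number of the three; the nearest is compound 3, the step being a 2.5-fold lower number from compound 1 to compound 3 (0.40 log units; beyond the scatter), and the furthest is compound 2, with a 4.0-fold lower number from compound 1 to compound 2 (0.61 log units; beyond the scatter). Compound 1 and compound 2 differ only in chloro in place of bromo on an aromatic carbon.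

The unmeasured compound is compound 4, `O=C(Nc1ccc(Oc2ccnc3[nH]ccc23)c(F)c1)c1nn(-c2ccc(Cl)cc2)ccc1=O`. It differs from compound 1 in fluoro in place of hydrogen on an aromatic carbon. The same kind of change was already made between two measured compounds: compound 3 differs from compound 2 in fluoro in place of hydrogen on an aromatic carbon. The two places are not identical: in compound 4 the fluoro is meta to a large group, whereas in compound 3 it is meta to a bromo group (1 heavy atom), so the change is of the same kind but not the same. In this assay that earlier step was a 1.6-fold higher number from compound 2 to compound 3 (0.20 log units; within the scatter), a difference that stays within the usual scatter of such measurements.

On that basis the step from compound 1 to compound 4 is expected to be small, estimated as a 1.2-fold higher number from compound 1 to compound 4 (0.07 log units; within the scatter), because the matching step a 1.6-fold higher number from compound 2 to compound 3 (0.20 log units; within the scatter) was itself within the scatter. Compound 4 is therefore estimated at 38000 nM, with a plausible range from 13000 nM to 110000 nM.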

Compound 4, half-maximal inhibitory concentration: 42500 nM
For compound 4 the middle estimate is 1.1-fold (0.05 log units) below the measured one, within the range that was stated.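

The new step is a 1.3-fold higher number from compound 1 to compound 4 (0.12 log units; within the scatter), measured in this assay, and like the earlier fluoro step it cannot be told apart from the ordinary spread of repeated measurements. Set side by side, the two steps agree, so in this small set fluoro in place of hydrogen carries from one core to the other as a change with no readable effect on the number: the same change on two cores in this assay, a 1.6-fold higher number (0.20 log units; within the scatter) from compound 2 to compound 3 and a 1.3-fold higher number (0.12 log units; within the scatter) from compound 1 to compound 4, 1.2-fold (0.08 log units) apart, within the scatter of two such steps

This does not show that fluoro makes no difference in general, since it rests on just two pairs of compounds, and the fluoro does not stand in the same place in both: in compound 4 it is ortho to one large group and meta to another, while in compound 3 it is meta to a bromo group.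

The compounds shown leave open whether a larger or different group at the place taken by the fluoro in compound 4, such as a methoxy group, an amine or a nitrile, would give a step beyond the scatter. They also leave open whether a bromo counterpart of compound 4 would keep the gain seen in a 4.0-fold lower number from compound 1 to compound 2 (0.61 log units; beyond the scatter).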